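A few compounds are considered here, and "the series" means these few. Any claim that something is new, unique, unknown or untested is made for them only; others in the source may bear on it.

Working notes on the series. In an assay on isolated protein for inhibition of malate dehydrogenase, mitochondrial (Sus scrofa), with stated times of 45 min and 30 min (on this read-out lower numbers stand for stronger inhibition and higher numbers for weaker inhibition), compound 2 `O=S(=O)(Nc1ccc(-c2nc3ccccc3o2)cc1)c1ccccc1O` gives only a limit, > 63000 nM. Compound 1 `O=S(=O)(Nc1ccc2oc(-c3ccccc3)nc2c1)c1ccc(Cl)c(Cl)c1` likewise gives only a limit in this assay, > 63000 nM. Every shown value thus sits at the same point, (the limit of > 63000 nM in this assay, at which 2 of the 2 values shown sit). Compound 3 `O=S(=O)(Nc1ccc(-c2nc3ccccc3o2)cc1)c1ccc(Cl)c(Cl)c1` differs from compound 2 by 3,4-dichlorophenyl in place of 2-hydroxyphenyl on a sulfonyl sulfur. No measured step sizes this change. Compound 1 already carries the 3,4-dichlorophenyl and still returns only a limit in this assay, > 63000 nM. No shift beyond the scatter is therefore expected from compound 2 to compound 3, a step that the limit leaves unreadable from compound 2 to compound 3. Compound 3 is expected to give about 100000 nM in this assay, between 30000 nM and 400000 nM, most likely reported again as a limit.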

Compound 3, half-maximal inhibitory concentration: > 63000 nM
Compound 3: a limit, no number (the forecaster's own chance of this, stated with the estimate: 85%); the middle value lies beyond the limit too.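

No step can be read between compound 2 and compound 3, as each gives only a limit: the limit of > 63000 nM in this assay, at which 3 of the 3 values shown sit.

The compounds shown leave open whether 3,4-dichlorophenyl and 2-hydroxyphenyl differ at all in their effect on inhibition.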